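Extending the Acetamido Chain: What to Expect for Cytotoxicity

This account rests on a few compounds, and the source may have more. Where it says the series, first, only, none or still open, it means among the compounds named here.

Compound 1 `CCCC(Nc1cncc(-c2ccc(O)c(OC)c2)n1)c1cccnc1` gives 300 nM in a functional assay on PC-3 cells (Homo sapiens) for cytotoxicity, read by MTT assay, with a stated time of 72 h; on this read-out lower numbers stand for stronger inhibition and higher numbers for weaker inhibition.
Compound 2 `CCCC(Nc1cncc(-c2ccc(NC(C)=O)c(OC)c2)n1)c1cccnc1` gives 5000 nM in this assay.

Compound 2 holds the higher of the two numbers, so on this read-out it is the weaker inhibitor of the pair. For the measured compounds named here, the single measured step, a 17-fold higher number from compound 1 to compound 2 (1.22 log units; beyond the scatter), replaces hydroxy with acetamido on an aromatic carbon and is a large one. Compound 3 `CCCC(=O)Nc1ccc(-c2cncc(NC(CCC)c3cccnc3)n2)cc1OC` is not yet measured; it differs from compound 2 by ethyl in place of hydrogen on a saturated chain carbon bound to a carbonyl carbon. Going by the values given here, no measured step touches this part of the molecule: the only step known, a 17-fold higher number from compound 1 to compound 2 (1.22 log units; beyond the scatter), concerns the group on the aromatic carbon, not the length of its acyl chain. Without a precedent, the cautious expectation is no change beyond the usual scatter, so compound 3 is expected to show no change at the digits printed from compound 2 to compound 3 (within the scatter). On that basis compound 3 is estimated at 5000 nM, with a likely range from 1500 nM to 15000 nM.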

Compound 3, half-maximal inhibitory concentration: 600 nM
Beside the measured number, compound 3's estimate is 8.3-fold (0.92 log units) above it; measured number outside the range, below it.
By their numbers in this assay, from the lowest: compounds 1 and 3 (each within the scatter of the next); then compound 2.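

In this assay, the acyl chain turns out to matter: ethyl in place of hydrogen on a saturated chain carbon bound to a carbonyl carbon, which turns acetamido into (propylcarbonyl)amino, gives an 8.3-fold lower number from compound 2 to compound 3 (0.92 log units; beyond the scatter). The large penalty seen with acetamido therefore does not extend to this longer acyl group, since replacing hydroxy with (propylcarbonyl)amino gives a 2.0-fold higher number from compound 1 to compound 3 (0.30 log units; within the scatter). No measurement shown here offers a reason for this shift in the numbers.

The compounds shown leave open how the number responds to chain length beyond this single change, as they include neither the intermediate propionyl group nor a longer chain such as hexanoyl. It is also unknown whether a branched isobutyryl group or a chain ending in an amine or a carboxylic acid would fit this position equally well.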